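Enlarging the Side Chain on the Shared Core

The source may report more compounds than this note shows. Statements on the series, on what has been measured and on what is new or still open speak of the compounds shown alone.

Measured so far:
compound 1, `OCCCNCc1nc2c(OCC3CCCCC3)cccc2[nH]1`, gives 52.7% in an assay on cells for inhibition of interleukin-5 receptor subunit alpha (Mus musculus), read by WST assay, with a stated time of 48 h, tested at 30 uM, in the presence of a further agent that is not named here; a higher number here means more inhibition at the concentration tested (going by the name of the read-out), a lower number less inhibition.
compound 2, `CCCC(CO)NCc1nc2c(OCC3CCCCC3)cccc2[nH]1`, gives 73.3% in this assay.

Among the compounds with values here, of the two numbers, compound 2 has the higher one, and the only measured step, a number 20.6 percentage points higher from compound 1 to compound 2 (beyond the scatter), lies beyond the scatter. Compound 3, `OCC(CC1CCCCC1)NCc1nc2c(OCC3CCCCC3)cccc2[nH]1`, keeps everything of compound 2 except one change: cyclohexyl in place of ethyl on a saturated chain carbon, two bonds along the chain from an amine nitrogen. Within the data shown here, the one step known so far exchanged the whole group on the amine nitrogen, whereas the new change alters the chain two bonds away from that nitrogen, so the earlier step bears on it only loosely. What it does show is that a larger side chain at this end of the molecule went with a higher number in this assay. With a single such step there is no firm pattern, so the expectation is a small rise or no change beyond the scatter rather than a large move. For compound 3 the value expected in this assay is 78%, with a range from 60% to 92%. The step this estimate implies is a number 4.7 percentage points higher from compound 2 to compound 3 (within the scatter).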

Compound 3, a percentage reported as inhibition, at one concentration (the size of the read-out at that concentration, not a potency): 94.7%
Estimate against measurement, compound 3: 16.7 percentage points below, and the stated range ends below it.
By their numbers in this assay, from the lowest: compound 1; then compound 2; then compound 3.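

In this assay, the change confined to the chain, with the amine nitrogen and the hydroxymethyl group left as they were, gives a number 21.4 percentage points higher from compound 2 to compound 3 (beyond the scatter), so this saturated chain carbon is a place where the number responds on its own, and not only when the whole group on the nitrogen is exchanged. It also shows that this end of the molecule can carry a six-membered non-aromatic ring of carbon only, in place of an open chain, with no loss in this read-out, and across the steps from compound 1 to compound 2 and from compound 2 to compound 3, no compound shown goes against a rise as the side chain grows. No measurement available here explains why the number rises at this position.

From the compounds shown here alone, what stays open is whether the ring itself matters or only the added carbon atoms, a question that a straight hexyl chain or a phenyl ring at the same place would help to settle. Compound 3 gives 94.7%, close to the top of a percentage scale at one concentration, so further gains at this position would be hard to see in this read-out, which is not a measure of potency.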